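Moving the hydroxylated ring one bond closer to the core

A few compounds are considered here, and "the series" means these few. Any claim that something is new, unique, unknown or untested is made for them only; others in the source may bear on it.

Of the compounds shown here, three sharing one core have been measured in an assay on isolated protein for inhibition of protein kinase C theta type (Homo sapiens), read by TR-FRET, with a stated time of 2 h; a lower number here means a stronger inhibitor, a higher number a weaker inhibitor. Compound 1 `N#Cc1cnc(NCc2cnccc2C(F)(F)F)cc1N[C@H]1C[C@@H](O)C1` gives 500 nM. Compound 2 `N#Cc1cnc(NCc2cnccc2C(F)(F)F)cc1N[C@H]1C[C@H](O)C1`, its mirror image, gives 900 nM; the step of a 1.8-fold higher number from compound 1 to compound 2 (0.26 log units; within the scatter). Compound 3 `N#Cc1cnc(NCc2cnccc2C(F)(F)F)cc1NC[C@H]1C[C@H](O)C1` gives 700 nM and stands second highest of the three numbers, with compound 2 nearest and compound 1 furthest, both within the scatter.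

Compound 4 `N#Cc1cnc(NCc2cnccc2C(F)(F)F)cc1N[C@H]1CC[C@@H](O)CC1` is the next compound in the series. Against compound 3 the change is 4-hydroxycyclohexyl in place of (3-hydroxycyclobutyl)methyl on a nitrogen on an aromatic ring. The nearest measured steps are those in which the hydroxycyclobutyl ring was attached directly to the nitrogen or through one extra carbon: a 1.4-fold higher number from compound 1 to compound 3 (0.15 log units; within the scatter) and a 1.3-fold lower number from compound 2 to compound 3 (0.11 log units; within the scatter). Both are small, so altering the size of the hydroxylated ring and dropping the linking carbon is expected to bring no change beyond the scatter in this assay. For compound 4 the expected step is a 1.2-fold lower number from compound 3 to compound 4 (0.07 log units; within the scatter), and compound 4 is estimated to give 600 nM, within a range from 250 nM to 1500 nM.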

Compound 4, half-maximal inhibitory concentration: 100 nM
The estimate for compound 4 lay 6.0-fold (0.78 log units) above the measured number; measured number outside the range, below it.
By their numbers in this assay, from the lowest: compound 4; then compounds 1, 3 and 2 (each within the scatter of the next).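

In this assay, 4-hydroxycyclohexyl on this nitrogen is the only change shown that moves the number beyond the scatter: a 7.0-fold lower number from compound 3 to compound 4 (0.85 log units; beyond the scatter), a 9.0-fold lower number from compound 2 to compound 4 (0.95 log units; beyond the scatter), and a 5.0-fold lower number from compound 1 to compound 4 (0.70 log units; beyond the scatter). Compounds 1, 2 and 3 alone suggested that this position barely responds, since neither the drawn configuration of the four-membered ring nor one extra linking carbon gave a step beyond the scatter, whereas compound 4 shows that the group on this nitrogen can matter. Nothing given here explains why the six-membered ring gives the lower number.

The compounds shown do not tell whether the hydroxyl itself is needed, as a plain cyclohexyl or a 4-aminocyclohexyl would be required to test that. They also leave open how a five-membered ring or the other configuration of 4-hydroxycyclohexyl would compare.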